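The compounds below may be only part of what the source reports. "The series", "measured", "known", "first", "only" and "open" are said of these compounds alone.

Three ureas of the shared core have been measured in a functional assay on MCF7 cells (Homo sapiens) for cytotoxicity, read by MTT assay, with a stated time of 48 h (a lower number here means a stronger inhibitor, a higher number a weaker inhibitor), so far. Compound 1 `COc1ccc(CN(C(=O)Nc2ccc(F)c(Cl)c2)n2cnnc2)cc1OC` gives 30100 nM. Compound 3 `Cc1ccsc1CN(C(=O)Nc1ccc(Cl)c(C(F)(F)F)c1)n1cnnc1` gives 30100 nM. Compound 2 `COc1ccc(OC)c(CN(C(=O)Nc2ccc(C)cc2)n2cnnc2)c1` returns only a limit, > 50000 nM, and not a number. On the numbers shown compound 2 thus sits at the limit of > 50000 nM in this assay, at which 1 of the 3 values shown sits, and nothing places it within the measured range.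

The next compound, compound 4 `COc1ccc(OC)c(CN(C(=O)NC2CCCCC2)n2cnnc2)c1`, differs from compound 2 in one place: cyclohexyl in place of 4-methylphenyl on an amide-type nitrogen. Among the compounds with values here, no measured step in this assay matches that change, so the expectation rests on the standing of compound 2 alone. With compound 2 at a limit, a move in either direction beyond the scatter cannot be told from the data, and the likeliest outcome is that compound 4 also comes back as a limit. In this assay the expected step that the limit leaves unreadable from compound 2 to compound 4 is therefore taken as none beyond the scatter. Compound 4 is estimated at 60000 nM in this assay, within a range from 20000 nM to 150000 nM.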

Compound 4, half-maximal inhibitory concentration: > 50000 nM
Compound 4 was reported as a limit; the forecaster's own chance of this, stated with the estimate: 70%; the middle value is on the limit's open side.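

No step can be read from compound 2 to compound 4 in this assay, as both compounds are reported only as limits. The compounds shown leave open what cyclohexyl in place of 4-methylphenyl on an amide-type nitrogen does to the value when both partners give a number.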